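A few compounds are considered here, and "the series" means these few. Any claim that something is new, unique, unknown or untested is made for them only; others in the source may bear on it.

Values measured in a functional assay on DU-145 cells (Homo sapiens) for inhibition, read by trypan blue exclusion, with a stated time of 96 h; on this read-out higher numbers stand for weaker inhibition of growth and lower numbers for stronger inhibition of growth:
- compound 1 `Cc1cc(C)cc(/C=C(/SCc2ccc(F)cc2)C(=O)c2ccc(Br)cc2)c1`: 10000 nM
- compound 2 `COc1ccccc1/C=C(/SCc1ccc(F)cc1)C(=O)c1ccc(Br)cc1`: 10000 nM
- compound 3 `COc1ccccc1/C=C(/SCc1ccc(Cl)cc1)C(=O)c1ccc([N+](=O)[O-])cc1`: 10000 nM

Compound 1 and compound 3 sit level with compound 2, at 10000 nM in this read-out. Compound 4 `O=C(/C(=C\c1c[nH]c2ccc(Cl)cc12)SCc1ccc(F)cc1)c1ccc(Br)cc1` changes compound 2 on a double-bonded chain carbon bound to a double-bonded chain carbon: 5-chloro-1H-indol-3-yl in place of 2-methoxyphenyl on a double-bonded chain carbon bound to a double-bonded chain carbon (5-chloro-1H-indol-3-yl in place of 2-methoxyphenyl).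

For the measured compounds named here, only one measured step touches this place, no change at the digits printed from compound 1 to compound 2 (within the scatter), and it shows that exchanging one benzene-type group for another moved nothing. Going by the values given here, no measured compound carries 5-chloro-1H-indol-3-yl, so the direction rests on little. A cautious guess leans toward stronger inhibition, with no change still possible. The expected step is a 3.3-fold lower number from compound 2 to compound 4 (0.52 log units; beyond the scatter) in this assay, and it is only an estimate. For compound 4 the estimated value is 3000 nM, with an expected range from 300 nM to 10000 nM here.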

Compound 4, concentration for 50% growth inhibition: 1000 nM
Compound 4: middle estimate off by 3.0-fold (0.48 log units), on the high side; the range from low to high includes it.
By their numbers in this assay, from the lowest: compound 4; then compounds 1, 2 and 3 (each within the scatter of the next).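

In this assay this position proves sensitive to its group: 5-chloro-1H-indol-3-yl gives a 10-fold lower number from compound 2 to compound 4 (1.00 log units; beyond the scatter) and a 10-fold lower number from compound 1 to compound 4 (1.00 log units; beyond the scatter), whereas exchanging 3,5-dimethylphenyl for 2-methoxyphenyl moved nothing. The entering group adds a five-membered aromatic ring, a chlorine and a hydrogen-bond donor together, so this change alone cannot show which of them matters. Nothing measured here explains the gain. Still open, from the compounds shown here alone, is whether plain 1H-indol-3-yl, without the chlorine, would keep this gain. Also open, going by these compounds, is how an amine or a carboxylic acid would behave at this position.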